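Homologating the picolinamide in a triazole-indole ghrelin antagonist

The compounds below may be only part of what the source reports. "The series", "measured", "known", "first", "only" and "open" are said of these compounds alone.

Within the data shown here, compound 2 `CCc1ccc(Cn2c(CCc3ccccc3)nnc2[C@H](NC(=O)c2ccccn2)c2c[nH]c3ccccc23)cc1` stands highest of the two numbers measured so far in a functional assay on CHO cells for antagonist activity at growth hormone secretagogue receptor type 1 (Homo sapiens); on this read-out lower numbers stand for stronger inhibition and higher numbers for weaker inhibition: compound 2 gives 513 nM, whereas compound 1 `COc1ccc(Cn2c(CCc3ccccc3)nnc2[C@H](NC(=O)c2ccccn2)c2c[nH]c3ccccc23)c(OC)c1` gives 25 nM. Among the measured compounds shown here, the one measured step, a 21-fold higher number from compound 1 to compound 2 (1.31 log units; beyond the scatter), concerns the group on the saturated chain carbon bound to an aromatic nitrogen and not the amide side of the molecule. Compound 3 `CCc1ccc(Cn2c(CCc3ccccc3)nnc2[C@H](NC(=O)Cc2ccccn2)c2c[nH]c3ccccc23)cc1` differs from compound 2 at the carbonyl carbon, where ((pyridin-2-yl)methyl in place of pyridin-2-yl on a carbonyl carbon). For the measured compounds named here, no measured step bears on this change, so its size cannot be read from the data; the account can only note that the single large step seen so far lay elsewhere in the core. In this assay compound 3 is therefore expected to land near 1500 nM, with a wide range from 300 nM to 8000 nM, which would mean a step of a 2.9-fold higher number from compound 2 to compound 3 (0.47 log units; beyond the scatter).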

Compound 3, antagonist equilibrium constant: 124 nM
Beside the measured number, compound 3's estimate is 12-fold (1.08 log units) above it; the measured number lies below the stated range.
By their numbers in this assay, from the lowest: compound 1; then compound 3; then compound 2.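

In this assay the position on the carbonyl carbon proves responsive: (pyridin-2-yl)methyl in place of pyridin-2-yl gives a 4.1-fold lower number from compound 2 to compound 3 (0.62 log units; beyond the scatter), a modest step but one beyond the scatter. Among these compounds, the earlier step concerned only the group on the saturated chain carbon, so this is the first sign that the amide side of the molecule also affects the number, and here the longer group gives the stronger inhibition. Nothing available explains this gain.

The compounds shown leave open whether the same change would also lower the number when made on compound 1, which carries 2,4-dimethoxyphenyl. They also leave open whether a still longer chain, such as 2-(pyridin-2-yl)ethyl, or a benzyl group, which has no ring nitrogen, would do better on the carbonyl carbon.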